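The source may report more compounds than this note shows. Statements on the series, on what has been measured and on what is new or still open speak of the compounds shown alone.

Working notes on the series. Within the data shown here, in a functional assay on MDA-MB-231 cells (Homo sapiens) for cytotoxicity, read by MTT assay, with a stated time of 48 h (on this read-out higher numbers stand for weaker inhibition and lower numbers for stronger inhibition), compound 2 `CC(C)n1c(/C=C2/C(=O)Nc3ccc(Cl)cc32)nc2ccccc21` gives 25100 nM and this is the only true number so far. Compound 1 `Cn1c(/C=C2/C(=O)Nc3ccc(Br)cc32)nc2ccccc21` is reported only as a limit at > 50000 nM in this assay and carries no number.

The next compound to read is compound 3 `Cn1c(/C=C2/C(=O)Nc3ccc(Cl)cc32)nc2ccccc21`. It departs from compound 2 with methyl in place of isopropyl on an aromatic nitrogen and the change sits next to the ring atom that bears a large group. Among the measured compounds shown here, no measured pair isolates this change, so any expectation rests on thin ground. Compound 1 also has methyl on that nitrogen, and its result of > 50000 nM is a limit, which points the expectation toward weaker inhibition.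

The expected move is a 1.6-fold higher number from compound 2 to compound 3 (0.20 log units; within the scatter) in this assay and this modest step toward weaker inhibition may not clear the usual scatter. For compound 3 the estimated value is 40000 nM with an expected range from 20000 nM to 80000 nM and a report as a limit alone is quite possible.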

Compound 3, half-maximal inhibitory concentration: 37600 nM
Estimate against measurement, compound 3: 1.1-fold (0.03 log units) above; low and high end bracket the measured number.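

In this assay, the change from isopropyl to methyl on the aromatic nitrogen can now be read directly as a 1.5-fold higher number from compound 2 to compound 3 (0.18 log units; within the scatter), so this pair does not separate the two groups at this position, and the size of the group on that nitrogen shows no clear link to the read-out across this one change. The change from bromo to chloro on an aromatic carbon gives an at least 1.3-fold lower number from compound 1 to compound 3 (0.12 log units; that floor lies within the scatter), and since this step rests on a limit and has only a floor, it puts no firm order on the two halogens. Compound 1 is reported only as a limit: the limit of > 50000 nM in this assay, at which 1 of the 3 values shown sits.

Still open, going by these compounds, is whether any group on that nitrogen can move the number beyond the scatter, for instance a longer chain such as n-butyl or a chain ending in an amine or a carboxylic acid. Also open, on these data alone, is how far the aromatic carbon that carries the halogen tolerates other groups, such as methoxy or a nitrile, and whether bromo and chloro would separate on a pair in which both values are true numbers.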